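The source may report more compounds than this note shows. Statements on the series, on what has been measured and on what is new or still open speak of the compounds shown alone.

In a functional assay on LS174T cells (Homo sapiens) for inhibition, read by MTT assay, with a stated time of 72 h (a higher number here means a weaker inhibitor, a lower number a stronger inhibitor), compound 1 `CCc1ccc(C(=O)/C=C/C(=O)O)cc1` gives 21000 nM, compound 2 `CC(C)c1ccc(C(=O)/C=C/C(=O)O)cc1` gives 25700 nM and compound 3 `CCCCc1ccc(C(=O)/C=C/C(=O)O)cc1` gives 6740 nM, the lowest number of the three. The measured steps are a 1.2-fold higher number from compound 1 to compound 2 (0.09 log units; within the scatter), a 3.1-fold lower number from compound 1 to compound 3 (0.49 log units; beyond the scatter) and a 3.8-fold lower number from compound 2 to compound 3 (0.58 log units; beyond the scatter). Compound 4 `CC(C)(C)c1ccc(C(=O)/C=C/C(=O)O)cc1` has tert-butyl in place of butyl on an aromatic carbon. The closest guide is a 3.8-fold lower number from compound 2 to compound 3 (0.58 log units; beyond the scatter), which also replaces a branched group with butyl. Run in reverse, it suggests a modest rise in this assay, of similar size and not certain to exceed the scatter by much. The expected move is a 2.4-fold higher number from compound 3 to compound 4 (0.38 log units; beyond the scatter). Compound 4 is estimated at 16000 nM, with an expected range of 7500 nM to 32000 nM.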

Compound 4, half-maximal inhibitory concentration: 8740 nM
The estimate for compound 4 lay 1.8-fold (0.26 log units) above the measured number, within the range that was stated.
By their numbers in this assay, from the lowest: compounds 3 and 4 (each within the scatter of the next); then compounds 1 and 2 (each within the scatter of the next).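

In this assay tert-butyl in place of butyl gives a 1.3-fold higher number from compound 3 to compound 4 (0.11 log units; within the scatter) and so leaves the number unchanged within the scatter at this aromatic carbon. Branching alone therefore does not decide the number, since the series also shows a 2.9-fold lower number from compound 2 to compound 4 (0.47 log units; beyond the scatter) for the added methyl and a 2.4-fold lower number from compound 1 to compound 4 (0.38 log units; beyond the scatter) for tert-butyl in place of ethyl. Both groups of 4 heavy atoms now give lower numbers than ethyl and isopropyl.

From the compounds shown here alone, whether a longer chain such as hexyl or a ring such as cyclohexyl would lower the number further stays open. No measurement on hand accounts for these differences.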